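Replacing the side group of compound 3

The compounds below may be only part of what the source reports. "The series", "measured", "known", "first", "only" and "open" are said of these compounds alone.

- compound 1 `COc1ccc(CN(C(=O)Cn2cc(COc3cc(=O)oc4ccccc34)nn2)c2cc(OC)c(OC)c(OC)c2)cc1`: 5140 nM
- compound 2 `COc1ccc(CN(C(=O)Cn2cc(CSC3=NCCS3)nn2)c2cc(OC)c(OC)c(OC)c2)cc1`: 16000 nM
- compound 3 `COc1ccc(CN(C(=O)Cn2cc(CSc3nc4ccccc4o3)nn2)c2cc(OC)c(OC)c(OC)c2)cc1`: 5050 nM

All three values come from a functional assay on PC-3 cells (Homo sapiens) for antiproliferative activity, read by MTT assay, with a stated time of 48 h; on this read-out higher numbers stand for weaker inhibition and lower numbers for stronger inhibition. Compound 3 stands level with compound 1, as a 1.0-fold lower number from compound 1 to compound 3 (0.01 log units; within the scatter) lies within the scatter, and a 3.2-fold lower number from compound 2 to compound 3 (0.50 log units; beyond the scatter) places it clearly ahead of compound 2.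

Compound 4 `COc1ccc(CN(C(=O)Cn2cc(CNS(=O)(=O)c3ccc(Br)cc3)nn2)c2cc(OC)c(OC)c(OC)c2)cc1` has not yet been measured. It carries ((4-bromophenyl)sulfonyl)amino in place of (1,3-benzoxazol-2-yl)sulfanyl on a saturated chain carbon bound to an aromatic carbon.

Within the data shown here, no measured compound carries this new group. The nearest evidence is two swaps at this place, a 1.0-fold lower number from compound 1 to compound 3 (0.01 log units; within the scatter) and a 3.1-fold higher number from compound 1 to compound 2 (0.49 log units; beyond the scatter), one within the scatter and one modest. In this assay the expected change is a 1.4-fold higher number from compound 3 to compound 4 (0.14 log units; within the scatter), a slight weakening at most within the scatter, though a modest step either way remains possible. For compound 4 the estimated value is 7000 nM, with an expected range of 2500 nM to 20000 nM.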

Compound 4, half-maximal inhibitory concentration: 12500 nM
Compound 4: the middle estimate sits 1.8-fold (0.25 log units) below what was measured, within the range that was stated.
By their numbers in this assay, from the lowest: compounds 3 and 1 (each within the scatter of the next); then compounds 4 and 2 (each within the scatter of the next).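

On this saturated chain carbon, ((4-bromophenyl)sulfonyl)amino loses ground in this assay with a 2.5-fold higher number from compound 3 to compound 4 (0.39 log units; beyond the scatter) and a 2.4-fold higher number from compound 1 to compound 4 (0.39 log units; beyond the scatter) while a 1.3-fold lower number from compound 2 to compound 4 (0.11 log units; within the scatter) leaves compound 4 level with compound 2 . Across these four compounds, the two groups with two rings now give the lower numbers and the two groups with one ring the higher numbers, and no compound goes against this. No measurement shown gives a reason for this split. Still open, as far as these compounds go, is whether the second ring itself matters or some other difference between these groups, and how a plain amine or a carboxylic acid would read here.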